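Swapping 3,5-Difluorophenyl for Phenyl

The compounds below may be only part of what the source reports. "The series", "measured", "known", "first", "only" and "open" are said of these compounds alone.

For the measured compounds named here, in a functional assay on MCF7 cells (Homo sapiens) for cytotoxicity (on this read-out higher numbers stand for weaker inhibition and lower numbers for stronger inhibition), compound 1 `C=C/C=C\[C@H](C)[C@H](OC(N)=O)[C@@H](C)[C@H](O)[C@@H](C)C/C(C)=C\[C@H](C)[C@@H](O)[C@@H](C)/C=C\CCc1cccc(Cl)c1` gives 400 nM and compound 2 `C=C/C=C\[C@H](C)[C@H](OC(N)=O)[C@@H](C)[C@H](O)[C@@H](C)C/C(C)=C\[C@H](C)[C@@H](O)[C@@H](C)/C=C\CCc1cc(F)cc(F)c1` gives 600 nM, so compound 2 stands within the scatter of its only neighbour. Compound 3 `C=C/C=C\[C@H](C)[C@H](OC(N)=O)[C@@H](C)[C@H](O)[C@@H](C)C/C(C)=C\[C@H](C)[C@@H](O)[C@@H](C)/C=C\CCc1ccccc1` differs from compound 2 in one place: phenyl in place of 3,5-difluorophenyl on a saturated chain carbon, two bonds along the chain from a double-bonded chain carbon. Going by the values given here, one measured step bears on this place, a 1.5-fold higher number from compound 1 to compound 2 (0.18 log units; within the scatter), and it exchanged one substituted phenyl for another. Among the compounds with values here, no compound with plain phenyl has been measured yet, so the evidence is thin. Nothing beyond the scatter is expected in this assay, and the expected step is a 1.2-fold lower number from compound 2 to compound 3 (0.08 log units; within the scatter). Compound 3 is estimated at 500 nM, with a range of 200 nM to 1200 nM.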

Compound 3, half-maximal inhibitory concentration: 480 nM
Beside the measured number, compound 3's estimate is 1.0-fold (0.02 log units) above it; the range from low to high includes it.
By their numbers in this assay, from the lowest: compounds 1, 3 and 2 (each within the scatter of the next).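

With plain phenyl available, the halogen-bearing rings can now be set against an unsubstituted ring: in this assay the data show a 1.3-fold lower number from compound 2 to compound 3 (0.10 log units; within the scatter), and also a 1.2-fold higher number from compound 1 to compound 3 (0.08 log units; within the scatter). On these numbers, neither the 3-chloro nor the 3,5-difluoro pattern separates from plain phenyl at this position. Nothing measured here says why these compounds read alike. Still open, on these data alone, is whether an amine or a carboxylic acid on the ring, or a longer chain leading to it, would move the number beyond the scatter.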